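A Thioether Swap on a Weakly Growth-Inhibiting Core

A few compounds are considered here, and "the series" means these few. Any claim that something is new, unique, unknown or untested is made for them only; others in the source may bear on it.

Measured so far:
compound 1 `Nc1cc(N)c2nc(-c3ccccc3)c(Oc3ccc(Cl)c(Cl)c3)nc2c1` 52500 nM
compound 2 `CCOC(=O)[C@H](CCC(=O)O)NC(=O)c1ccc(Sc2nc3cc(N)cc(N)c3nc2-c2ccccc2)cc1` 44700 nM

In a functional assay on SF-268 cells (Homo sapiens) for inhibition, read by sulforhodamine B assay, with a stated time of 48 h (a higher number here means a weaker inhibitor of growth, a lower number a stronger inhibitor of growth), compound 1 gives 52500 nM, and compound 2 gives 44700 nM; the two numbers sit within the usual scatter of each other, so neither can be placed above the other. Compound 3 `Nc1cc(N)c2nc(-c3ccccc3)c(Sc3ccc(F)cc3)nc2c1` has not yet been measured. It differs from compound 1 in one place: (4-fluorophenyl)sulfanyl in place of 3,4-dichlorophenoxy on an aromatic carbon. Among the measured compounds shown here, no step between measured compounds is available to anchor this change, and compound 2 gives 44700 nM, close to compound 1. Compound 3 is therefore expected to give 35000 nM, with a range from 12000 nM to 100000 nM. The expected step of a 1.5-fold lower number from compound 1 to compound 3 (0.18 log units; within the scatter) is small, toward a lower number, and not beyond the scatter.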

Compound 3, concentration for total growth inhibition: 38900 nM
The estimate for compound 3 lay 1.1-fold (0.05 log units) below the measured number, and the stated range covers the measured number.
By their numbers in this assay, from the lowest: compounds 3, 2 and 1 (each within the scatter of the next).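

In this assay the swap of 3,4-dichlorophenoxy for (4-fluorophenyl)sulfanyl on this aromatic carbon gives a step that stays within the scatter (a 1.3-fold lower number from compound 1 to compound 3 (0.13 log units; within the scatter)). This position therefore tolerates a new linking atom and a new halogen pattern together without separating the two compounds, though the two changes cannot be told apart. Nothing available here explains this result. Still open, from the compounds shown here alone, is whether an amine, a carboxylic acid or a longer chain on this carbon would produce a step beyond the scatter.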